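The source may hold more compounds than are shown below. What is called first, only, known or untested is meant among the compounds shown, and "the series" means these compounds.

Going by the values given here, compound 2 `COc1ccc(OC)c(-c2cc(-c3ccc(C(=O)N4CCCC4)s3)on2)c1` is one of two compounds measured. In a functional assay on A549 cells (Homo sapiens) for cytotoxicity, read by XTT assay, with a stated time of 72 h (on this read-out lower numbers stand for stronger inhibition and higher numbers for weaker inhibition), compound 2 gives no number but only a limit, > 30000 nM. Among the compounds with values here, its one measured neighbour is compound 1 `CCCN(C)C(=O)c1ccc(-c2cc(-c3cc(OC)ccc3OC)no2)s1`, which differs from it at the carbonyl carbon only. In this assay compound 1 likewise gives only a limit, > 30000 nM. The step that the two limits leave unreadable from compound 1 to compound 2 is therefore unreadable, its size hidden because both values sit at the limit of > 30000 nM in this assay, at which 2 of the 2 values shown sit.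

Compound 3 `CCN(CC)C(=O)c1ccc(-c2cc(-c3cc(OC)ccc3OC)no2)s1` is the next compound and has not been measured. It differs from compound 2 by diethylamino in place of pyrrolidin-1-yl on a carbonyl carbon. Within the data shown here, the only measured step that bears on this change is the one from compound 1 to compound 2, and its size cannot be read from two limits. The shown numbers give no sign that this change should bring the value into the readable range, so the step expected for compound 3 in this assay is a step that the limit leaves unreadable from compound 2 to compound 3, meaning none beyond the scatter. Compound 3 is accordingly estimated at 50000 nM, with a range from 20000 nM to 200000 nM, and most likely reported again only as a limit.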

Compound 3, half-maximal inhibitory concentration: 11000 nM
For compound 3 the middle estimate is 4.5-fold (0.66 log units) above the measured one; measured number outside the range, below it.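

In this assay, the carbonyl carbon turns out to be a place where a single change can bring a value into the readable range, which the two earlier compounds could not show: compound 3 gives 11000 nM. Diethylamino in place of pyrrolidin-1-yl on that carbon gives an at least 2.7-fold lower number from compound 2 to compound 3 (0.43 log units; beyond the scatter), and diethylamino in place of methyl(propyl)amino gives an at least 2.7-fold lower number from compound 1 to compound 3 (0.43 log units; beyond the scatter), so the open-chain diethylamino group differs in this read-out from both the ring and the other open-chain group. Compound 1 and compound 2 both stop at a limit, so the step between them cannot be read and the two new steps give only a minimum size: the limit of > 30000 nM in this assay, at which 2 of the 3 values shown sit.

As far as these compounds go, how far the true steps extend therefore stays open, as does the question of whether the gain belongs to diethylamino alone or would also appear with groups such as dipropylamino, piperidin-1-yl or morpholin-4-yl on the same carbonyl carbon. The compounds shown also leave open whether a change elsewhere on the shared core, such as an amine or a carboxylic acid in place of a methoxy group, would move the value in this assay.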